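Compound 2 to compound 3: one ring exchanged

The source may report more compounds than this note shows. Statements on the series, on what has been measured and on what is new or still open speak of the compounds shown alone.

Compound 1 `O=C1CC(Oc2ncccn2)CN1c1cnn2c1CN(C(=O)Nc1cc(F)c(F)c(F)c1)C(C1CC1)C2` gives 0.95 h
Compound 2 `O=C1CC(c2ncco2)CN1c1cnn2c1CN(C(=O)Nc1cc(F)c(F)c(F)c1)C(C1CC1)C2` gives 3.7 h

Both values come from an ADME assay on the whole organism (Mus musculus, strain ICR) for metabolic stability, at a dose of 50 mg/kg by the oral route; on this read-out higher numbers stand for a longer-lived compound and lower numbers for a shorter-lived compound. Compound 2 holds the higher of the two numbers. The next candidate, compound 3 `O=C1CC(c2ncccn2)CN1c1cnn2c1CN(C(=O)Nc1cc(F)c(F)c(F)c1)C(C1CC1)C2`, has not yet been measured. It differs from compound 2 in one group: pyrimidin-2-yl in place of 1,3-oxazol-2-yl on a saturated ring carbon. Thus pyrimidin-2-yl stands in place of 1,3-oxazol-2-yl on a saturated ring carbon.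

For the measured compounds named here, only one measured step bears on this change, and only indirectly: a 3.9-fold higher number from compound 1 to compound 2 (0.59 log units; beyond the scatter), a modest step beyond the scatter. Compound 1 carries (pyrimidin-2-yl)oxy, so it shares the pyrimidine ring with compound 3, but the ring is attached through an oxygen that compound 3 lacks. Going by the values given here, no measured pair isolates the exchange of the two rings, so the earlier step cannot be carried over whole. Only a part of it is expected to return, in the downward direction. The expected change is a 1.5-fold lower number from compound 2 to compound 3 (0.19 log units; within the scatter), a small drop that may well stay within the scatter. For compound 3 the estimated half-life is 2.4 h, with an expected range from 1 h to 5.5 h.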

Compound 3, half-life: 0.87 h
Compound 3: the middle estimate sits 2.8-fold (0.44 log units) above what was measured, outside the stated range (below it).
By their numbers in this assay, from the lowest: compounds 3 and 1 (each within the scatter of the next); then compound 2.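

In this assay, the exchange of the two rings on this saturated ring carbon can now be read directly: pyrimidin-2-yl in place of 1,3-oxazol-2-yl gives a 4.3-fold lower number from compound 2 to compound 3 (0.63 log units; beyond the scatter), so the ring itself makes a difference beyond the scatter at this position. Whether the pyrimidine ring stands directly on the carbon or is attached through an oxygen makes no readable difference, since pyrimidin-2-yl in place of (pyrimidin-2-yl)oxy gives a 1.1-fold lower number from compound 1 to compound 3 (0.04 log units; within the scatter), and among these three compounds only compound 2, the one carrying 1,3-oxazol-2-yl, stands apart in half-life. Nothing in the data at hand explains why the half-life follows this exchange of rings.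

The compounds shown leave open whether the higher number belongs to 1,3-oxazol-2-yl alone or would extend to other five-membered aromatic rings, such as thiazol-2-yl or imidazol-2-yl. They also leave open what a group of another kind on this saturated ring carbon, such as an amine or a carboxylic acid, would give in this assay.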